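A few compounds are considered here, and "the series" means these few. Any claim that something is new, unique, unknown or untested is made for them only; others in the source may bear on it.

This account follows the change from compound 1 `C=CCN(CCCC(=O)O)C(=O)/C(C)=C/c1ccc(C(=O)Oc2ccc(C(=N)N)cc2)cc1` to compound 3 `C/C(=C\c1ccc(C(=O)Oc2ccc(C(=N)N)cc2)cc1)C(=O)N(CC(=O)O)C1CCCCC1` in an in vitro ADME assay on a cell-free system (plasma) for pharmacokinetics; on this read-out higher numbers stand for a longer-lived compound and lower numbers for a shorter-lived compound. In this assay compound 1 gives only a limit, > 1 h, so its half-life is not known as a number, and it stands at the limit of > 1 h in this assay, at which 1 of the 2 values shown sits. A second compound measured alongside it, compound 2 `CCOC(=O)CN(C(=O)/C(C)=C/c1ccc(C(=O)Oc2ccc(C(=N)N)cc2)cc1)C1CCCC1`, also returns a limit, < 0.0834 h, at the other end of the range, at the limit of < 0.0834 h in this assay, at which 1 of the 2 values shown sits. Compound 1 and compound 2 differ in more than one place, so their two values show only that one sits at the long-lived end and the other at the short-lived end of what this assay reports. The change from compound 1 to compound 3 is (carboxymethyl)(cyclohexyl)amino in place of allyl(3-carboxypropyl)amino on a carbonyl carbon. Among the compounds with values here, no measured pair spans this change, so its effect in this assay is not known from any measured step. Both compound 1 and compound 3 carry the carboxy group named in that change. The step from compound 1 to compound 3 is expected to be a step that the limit leaves unreadable from compound 1 to compound 3, no more than the scatter, since compound 1 stands at the limit of > 1 h in this assay, at which 1 of the 2 values shown sits. Compound 3 is therefore estimated at 2 h, with a range from 0.5 h to 8 h, and a fair chance that this assay again reports only a limit.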

Compound 3, half-life: > 1 h
Compound 3: a limit, no number; the forecaster's own chance of this, stated with the estimate: 60%; the middle value lies beyond the limit too.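

In this assay compound 3 gives > 1 h, which is a limit and not a number. Within the data shown here, compound 1 also stands at a limit, so no step from compound 1 to compound 3 can be read. The compounds shown leave open how far apart their half-lives lie, and what (carboxymethyl)(cyclohexyl)amino in place of allyl(3-carboxypropyl)amino does on its own.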